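The source may hold more compounds than are shown below. What is called first, only, known or untested is meant among the compounds shown, and "the series" means these compounds.

Measured compounds:
- compound 1, `Cc1cc(F)cc(-c2cncc(-c3nc4cc(F)ccc4[nH]3)c2N2CCC(N)CC2)c1`, 0.019 nM
- compound 2, `Cc1nc(C(=O)Nc2cncc(-c3cc(Cl)cc(Cl)c3)c2N2CCC(N)CC2)c(C)o1`, 0.47 nM
- compound 3, `Cc1cc(C)cc(C(=O)Nc2cncc(-c3cc(C)cc(C)c3)c2N2CCC(N)CC2)c1`, 0.04 nM

Three compounds share a core and have been run in a functional assay on CHO-K1 cells for agonist activity at somatostatin receptor type 2 (Homo sapiens), read by cAMP accumulation, with a stated time of 30 min; a higher number here means that more compound is needed for the effect, a lower number that less compound is needed. Compound 2 has the highest number of the three: compound 3 sits below it by a gap beyond the usual scatter, and compound 1 sits further below still, also beyond the scatter. Compound 2 and compound 3 both carry an amide on the core; compound 2 carries 2,5-dimethyl-1,3-oxazol-4-yl on the carbonyl carbon, compound 3 a 3,5-dimethylphenyl there, and compound 2 also has chlorine where compound 3 has methyl on its other aryl ring, so no single change separates the two.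

Compound 4, `Cc1cc(C(=O)Nc2cncc(-c3cc(Cl)cc(Cl)c3)c2N2CCC(N)CC2)n(C)n1`, has not yet been measured. It differs from compound 2 in one place: 1,3-dimethyl-1H-pyrazol-5-yl in place of 2,5-dimethyl-1,3-oxazol-4-yl on a carbonyl carbon. Within the data shown here, no pair among the measured compounds isolates a swap of this kind, so nothing here shows how large an effect it has. With one five-membered aromatic ring with 2 hetero atoms replaced by another of the same size and acceptor count, the step is expected to be small, most likely within the scatter in either direction. The expected step from compound 2 to compound 4 is therefore a 1.1-fold higher number from compound 2 to compound 4 (0.03 log units; within the scatter), and compound 4 is estimated at 0.5 nM, between 0.15 nM and 1.6 nM.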

Compound 4, half-maximal effective concentration: 0.041 nM
Estimate against measurement, compound 4: 12-fold (1.09 log units) above; measured number below the stated range.
By their numbers in this assay, from the lowest: compound 1; then compounds 3 and 4 (each within the scatter of the next); then compound 2.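

In this assay, the group on the carbonyl carbon of the amide proves to be a place where a change of ring matters: 1,3-dimethyl-1H-pyrazol-5-yl in place of 2,5-dimethyl-1,3-oxazol-4-yl gives an 11-fold lower number from compound 2 to compound 4 (1.06 log units; beyond the scatter), with the rest of the molecule unchanged. This pair is the first among the compounds shown to isolate this position, and it shows that two five-membered aromatic rings with the same number of heavy atoms, hetero atoms and hydrogen-bond acceptors are not interchangeable here, so these counts alone do not tell how such a swap will turn out. No measurement at hand accounts for the size of this step.

The two rings differ both in their hetero atoms and in where their methyl groups sit, so the pair cannot show which of these differences carries the step, and a ring such as 1-methyl-1H-pyrazol-5-yl or 3,5-dimethylisoxazol-4-yl on the same carbonyl carbon would be needed to pull them apart. Also open, from the compounds shown here alone, is whether the swap gives a step of similar size when the other aryl ring carries methyl rather than chlorine.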